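The source may hold more compounds than are shown below. What is called first, only, known or untested is meant among the compounds shown, and "the series" means these compounds.

Measured compounds:
compound 1 `CS(=O)(=O)c1ccc(Cl)cc1NCC1=NCCN1`: 81%
compound 2 `COc1ccc(SC)c(NCC2=NCCN2)c1`: 74%
compound 3 `Cc1ccc(S(C)(=O)=O)c(NCC2=NCCN2)c1`: 76%

In a functional assay on CHO cells for agonist activity at Alpha-2C adrenergic receptor (Homo sapiens) (a higher number here means a larger maximal response, a lower number a smaller maximal response), compound 3 gives 76%, close to compound 2 with 74% and to compound 1 with 81%; the spread across all three stays within the usual scatter.

Compound 4 `COc1ccc(S(C)(=O)=O)c(NCC2=NCCN2)c1` differs from compound 3 by methoxy in place of methyl on an aromatic carbon. Within the data shown here, one measured step concerns a substituent exchange on this ring, a number 5 percentage points lower from compound 1 to compound 3 (within the scatter), and it stayed within the scatter. Among the measured compounds shown here, compound 2, which carries methoxy, and compound 3 show values within the scatter of each other, but they differ in more than one place, so no single step connects them. Nothing here points to a shift beyond the scatter in this assay.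

Compound 4 is therefore expected at 76%, with a range of 63% to 88%. The expected step is no change at the digits printed from compound 3 to compound 4 (within the scatter).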

Compound 4, largest response reached (reported as maximum), in percent of the reference or control that the assay uses: 49%
Compound 4: middle estimate off by 27 percentage points, on the high side; measured number below the stated range.
By their numbers in this assay, from the lowest: compound 4; then compounds 2, 3 and 1 (each within the scatter of the next).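

Among these compounds, on the aromatic carbon para to the methylsulfonyl group, methoxy brings the first change beyond the scatter in this assay, with a number 27 percentage points lower from compound 3 to compound 4 (beyond the scatter) and a number 32 percentage points lower from compound 1 to compound 4 (beyond the scatter), whereas the exchange of chloro for methyl gave only a number 5 percentage points lower from compound 1 to compound 3 (within the scatter). With methoxy kept, methylsulfonyl in place of methylsulfanyl also lowers the response, with a number 25 percentage points lower from compound 2 to compound 4 (beyond the scatter), so among these compounds the low value appears only where methoxy and methylsulfonyl occur together. Nothing available accounts for this result. As far as these compounds go, whether an amine or a hydroxyl group at this carbon would follow methoxy or methyl remains open, as does the effect of an ethoxy group.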